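The source may hold more compounds than are shown below. What is called first, only, known or untested is meant among the compounds shown, and "the series" means these compounds.

Of the compounds shown here, two have been tested so far in an ADME assay on MDCK cells (Canis lupus familiaris) for cytotoxicity, read by MTT assay, with a stated time of 24 h; a higher number here means that more compound is tolerated, a lower number that less compound is tolerated. Compound 1 `O=[N+]([O-])c1ccc(S(=O)(=O)NCc2ccoc2)cc1` gives > 236000 nM, which is a limit of the assay and not a number. Compound 2 `O=[N+]([O-])c1ccc(S(=O)(=O)NCc2csc3ccccc23)cc1` gives > 191000 nM, also a limit and not a number. Among the compounds with values here, compound 2 therefore stands only at a limit, as does the one other value available, and no step between measured compounds is known.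

Compound 3 `Cc1ccc(S(=O)(=O)NCc2csc3ccccc23)cc1` has methyl in place of nitro on an aromatic carbon of compound 2, para to a large group: methyl in place of nitro on an aromatic carbon. In this assay, no step beyond the usual scatter is expected. This expectation rests on compound 2, whose > 191000 nM is a limit. The estimated change is a step that the limit leaves unreadable from compound 2 to compound 3. Compound 3 is expected to give 200000 nM, with an estimated range of 90000 nM to 300000 nM.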

Compound 3, half-maximal cytotoxic concentration: > 210000 nM
Compound 3 was reported as a limit; the forecaster's own chance of this, stated with the estimate: 75%; at least 1.0-fold (0.02 log units) between middle value and limit.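

Compound 2 and compound 3 are both reported only as limits in this assay, and no step can be read between them. The compounds shown leave open how much of any of them is tolerated, and whether methyl in place of nitro on an aromatic carbon changes that at all.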